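A Hydroxyphenyl Variant of a Boron-Bearing Enone Series

The source may hold more compounds than are shown below. What is called first, only, known or untested is meant among the compounds shown, and "the series" means these compounds.

Within the data shown here, compound 3 `Cc1ccc(C(=O)/C=C/c2ccc3c(c2)B(O)OC3)cc1` stands second highest of the three numbers so far in a functional assay on SK-OV-3 cells (Homo sapiens) for cytotoxicity, read by MTT assay, with a stated time of 48 h (a higher number here means a weaker inhibitor, a lower number a stronger inhibitor), where compound 3 gives 3700 nM. Its nearest neighbour is compound 1 `O=C(/C=C/c1ccc2c(c1)B(O)OC2)c1ccccc1`, which in this assay gives 3400 nM; the step of a 1.1-fold higher number from compound 1 to compound 3 (0.04 log units; within the scatter) lies within the scatter. The furthest is compound 2 `O=C(/C=C/c1ccc2c(c1)B(O)OC2)c1cccnc1`, which in this assay gives 18500 nM; the step of a 5.0-fold lower number from compound 2 to compound 3 (0.70 log units; beyond the scatter) is modest but beyond the scatter.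

Compound 4 `O=C(/C=C/c1ccc2c(c1)B(O)OC2)c1cccc(O)c1` differs from compound 3 in one place: 3-hydroxyphenyl in place of 4-methylphenyl on a carbonyl carbon. Among the measured compounds shown here, two measured steps bear on this change. The step of a 1.1-fold higher number from compound 1 to compound 3 (0.04 log units; within the scatter) shows that the methyl on the aromatic carbon made no difference beyond the scatter. The step of a 5.4-fold higher number from compound 1 to compound 2 (0.74 log units; beyond the scatter) shows that the only ring on the carbonyl carbon carrying a hydrogen-bond acceptor gave a modestly higher number. The incoming 3-hydroxyphenyl brings one hydrogen-bond donor and one acceptor, which neither measured step matches exactly, so only a weak lean towards a higher number can be drawn. Compound 4 is therefore expected to give about 5500 nM, within a range from 2200 nM to 15000 nM. That expectation amounts to a step of a 1.5-fold higher number from compound 3 to compound 4 (0.17 log units; within the scatter), which may or may not exceed the scatter.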

Compound 4, half-maximal inhibitory concentration: 3800 nM
Compound 4: middle estimate off by 1.4-fold (0.16 log units), on the high side; measured number inside the range.
By their numbers in this assay, from the lowest: compounds 1, 3 and 4 (each within the scatter of the next); then compound 2.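

Read in this assay, the step of a 1.0-fold higher number from compound 3 to compound 4 (0.01 log units; within the scatter) and the step of a 1.1-fold higher number from compound 1 to compound 4 (0.05 log units; within the scatter) both lie within the scatter, so at this place on the carbonyl carbon the 3-hydroxyphenyl ring, with its hydrogen-bond donor and acceptor, cannot be told apart from either the 4-methylphenyl ring or the plain phenyl ring. Among these compounds, the step of a 4.9-fold lower number from compound 2 to compound 4 (0.69 log units; beyond the scatter) is modest but beyond the scatter, which shows that a hydrogen-bond acceptor on this ring does not by itself go with a higher number, and leaves compound 2 as the one compound of the four that stands apart. Nothing available explains why the pyridin-3-yl ring stands apart while the three other rings do not.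

The compounds shown leave open whether a ring carrying an amine or a carboxylic acid at this place would stay with compounds 1, 3 and 4 or move towards compound 2. They also leave open whether a 4-hydroxyphenyl or a pyridin-4-yl ring on the same carbonyl carbon would give a number like that of compound 4 or like that of compound 2.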